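Chloro for Fluoro on a Pendant Phenyl Ring

The source may hold more compounds than are shown below. What is called first, only, known or untested is meant among the compounds shown, and "the series" means these compounds.

Measured compounds:
- compound 1, `Fc1cc(Nc2cc(Nc3ccc(Cl)cc3)ncn2)ccc1Oc1ccncc1-c1cccnc1`: 240 nM
- compound 2, `Fc1ccc(Nc2cc(Nc3ccc(Oc4ccncc4-c4cccnc4)c(F)c3)ncn2)cc1`: 160 nM
- compound 3, `O=C(Nc1ccc(Oc2ccncc2-c2cccnc2)c(F)c1)c1nn(-c2ccc(F)cc2)c(=O)c2ccccc12`: 320 nM

All three were tested in a functional assay on MKN-45 cells (Homo sapiens) for cytotoxicity, read by MTT assay, with a stated time of 72 h; a higher number here means a weaker inhibitor, a lower number a stronger inhibitor. Compound 2 and compound 1 share a core and differ in one place, (chloro in place of fluoro on an aromatic carbon). That change gave a 1.5-fold higher number from compound 2 to compound 1 (0.18 log units; within the scatter), so in this assay the two compounds cannot be told apart. Compound 3 carries a different core; how it differs from compound 2 is not broken down here. In this assay compound 3 gives 320 nM, a number lying within the usual scatter of the other two.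

Compound 4, `O=C(Nc1ccc(Oc2ccncc2-c2cccnc2)c(F)c1)c1nn(-c2ccc(Cl)cc2)c(=O)c2ccccc12`, has not yet been measured. It is made from compound 3 by chloro in place of fluoro on an aromatic carbon, the same change that turned compound 2 into compound 1, and it sits in the same kind of place on the ring. For the measured compounds named here, the only guide is that earlier pair: because a 1.5-fold higher number from compound 2 to compound 1 (0.18 log units; within the scatter) was a small step, the same change on the core of compound 3 is expected to leave the number roughly where it is. The step from compound 3 to compound 4 is therefore estimated to be a 1.3-fold higher number from compound 3 to compound 4 (0.12 log units; within the scatter). Compound 4 is expected to give about 420 nM in this assay, most likely between 200 nM and 900 nM, with one untested core as the only basis for carrying the earlier result across.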

Compound 4, half-maximal inhibitory concentration: 430 nM
Compound 4: the middle estimate sits 1.0-fold (0.01 log units) below what was measured; low and high end bracket the measured number.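

In this assay, replacing 4-fluorophenyl with 4-chlorophenyl gave a 1.3-fold higher number from compound 3 to compound 4 (0.13 log units; within the scatter), a step too small to tell the two compounds apart. Set beside the earlier pair, the change looks the same on both cores, with no difference that can be read between the two steps: the same change on two cores in this assay, a 1.5-fold higher number (0.18 log units; within the scatter) from compound 2 to compound 1 and a 1.3-fold higher number (0.13 log units; within the scatter) from compound 3 to compound 4, 1.1-fold (0.05 log units) apart, within the scatter of two such steps. This shows that, on these two cores and in this one test, swapping fluoro for chloro left the number within the usual scatter, but two small steps are thin support for a rule, and they do not show that the swap would stay this small on any other core or say why it is small.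

As far as these compounds go, what a methyl, a methoxy, a nitrile or an amine in place of the chloro or fluoro would do to the number remains open, as does whether any group there could shift it beyond the scatter. Also open, from the compounds shown here alone, is whether a larger change at this spot would carry from one core to the other as closely as this one did.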